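A few compounds are considered here, and "the series" means these few. Any claim that something is new, unique, unknown or untested is made for them only; others in the source may bear on it.

For the measured compounds named here, in a functional assay on HCC827 cells (Homo sapiens) for antiproliferative activity, read by MTT assay, with a stated time of 72 h (on this read-out higher numbers stand for weaker inhibition and lower numbers for stronger inhibition), compound 3 `CN1CCN(c2ccc(Nc3ncc4nc(Nc5ccccc5)n([C@H]5CCN(C(=O)OC(C)(C)C)C5)c4n3)cc2)CC1` gives 110 nM, the highest number of the three measured so far, while compound 1 `CN1CCN(c2ccc(Nc3ncc4nc(Nc5ccc(F)cc5)n([C@H]5CCCNC5)c4n3)cc2)CC1` gives 38 nM and compound 2 `CN1CCN(c2ccc(Nc3ncc4nc(Nc5ccc(F)cc5)n(-c5cccc(NC(=O)CO)c5)c4n3)cc2)CC1` gives 7.5 nM. Compound 4 `CN1CCN(c2ccc(Nc3ncc4nc(Nc5ccccc5)n([C@H]5CCN(S(C)(=O)=O)C5)c4n3)cc2)CC1` carries methylsulfonyl in place of tert-butoxycarbonyl on an amine nitrogen in a ring. Going by the values given here, no measured step touches that nitrogen. Among the compounds with values here, the only step available is a 5.1-fold lower number from compound 1 to compound 2 (0.70 log units; beyond the scatter), a modest change of a whole group on an aromatic nitrogen, so it bears on this change only loosely. A smaller step toward a lower number is therefore expected, though one within the scatter remains possible. The estimated step is a 1.7-fold lower number from compound 3 to compound 4 (0.23 log units; within the scatter). For compound 4 the expected value is 65 nM, within an estimated range from 22 nM to 190 nM.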

Compound 4, half-maximal inhibitory concentration: 17 nM
Beside the measured number, compound 4's estimate is 3.8-fold (0.58 log units) above it; measured number below the stated range.
By their numbers in this assay, from the lowest: compound 2; then compound 4; then compound 1; then compound 3.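

In this assay, for the compounds shown here, the amine nitrogen in the five-membered non-aromatic ring responds clearly to the group it carries: methylsulfonyl in place of tert-butoxycarbonyl gives a 6.5-fold lower number from compound 3 to compound 4 (0.81 log units; beyond the scatter), the only measured step at this nitrogen. The step therefore shows that tert-butoxycarbonyl is not the best-performing of the two groups here, and that a group of 4 heavy atoms can replace one of 7 with no loss. Nothing available explains this step. The compounds shown leave open how a free amine, an acetyl group or a longer alkylsulfonyl chain on this nitrogen would compare.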